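Removing both methoxy groups from the anilino arm

The source may report more compounds than this note shows. Statements on the series, on what has been measured and on what is new or still open speak of the compounds shown alone.

Measured compounds:
compound 1, `COc1ccc(Nc2ncnc3cc(OC)c(OCCCCC(=O)Nc4ccc(S(N)(=O)=O)cc4)cc23)cc1`, in a functional assay on A-431 cells (Homo sapiens) for antiproliferative activity, read by MTT assay, with a stated time of 72 h; a lower number here means a stronger inhibitor, a higher number a weaker inhibitor: 14700 nM
compound 2, `COc1ccc(Nc2ncnc3cc(OC)c(OCCCCC(=O)Nc4ccc(S(N)(=O)=O)cc4)cc23)cc1OC`, in this assay: 35400 nM

Among the two measured compounds, compound 2 holds the higher number; its nearest neighbour is compound 1, and the step between them, a 2.4-fold higher number from compound 1 to compound 2 (0.38 log units; beyond the scatter), lies beyond the scatter, with a methoxy in place of hydrogen on an aromatic carbon. Compound 3, `COc1cc2ncnc(Nc3ccccc3)c2cc1OCCCCC(=O)Nc1ccc(S(N)(=O)=O)cc1`, differs from compound 2 by phenyl in place of 3,4-dimethoxyphenyl on a nitrogen on an aromatic ring.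

Going by the values given here, only one measured step bears on this change. Going from compound 1 to compound 2 added a methoxy and gave a modestly higher number, as a 2.4-fold higher number from compound 1 to compound 2 (0.38 log units; beyond the scatter) shows. The change to compound 3 runs the other way and further, removing both methoxy groups of the 3,4-dimethoxyphenyl. Among the compounds with values here, the expectation is therefore a lower number in this assay, of modest size, somewhat beyond the scatter, though only one step supports it.

Compound 3 is estimated at 11000 nM in this assay, within 4000 nM to 30000 nM, an expected step of a 3.2-fold lower number from compound 2 to compound 3 (0.51 log units; beyond the scatter).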

Compound 3, half-maximal inhibitory concentration: 25200 nM
The estimate for compound 3 lay 2.3-fold (0.36 log units) below the measured number, and the stated range covers the measured number.
By their numbers in this assay, from the lowest: compounds 1, 3 and 2 (each within the scatter of the next, the first and the last beyond it).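

In this assay, taking both methoxy groups off the 3,4-dimethoxyphenyl arm gives a 1.4-fold lower number from compound 2 to compound 3 (0.15 log units; within the scatter), so at this place on the nitrogen, phenyl and 3,4-dimethoxyphenyl cannot be told apart. The other comparison, with hydrogen in place of methoxy on an aromatic carbon, gives a 1.7-fold higher number from compound 1 to compound 3 (0.23 log units; within the scatter), so the compound with no methoxy on this arm cannot be told apart from the one with a single methoxy either. Going by these compounds alone, the only step beyond the scatter therefore remains a 2.4-fold higher number from compound 1 to compound 2 (0.38 log units; beyond the scatter), and the compound without methoxy groups does not extend it into a trend, while nothing available here explains this flat result.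

What the three compounds leave open is whether any group on this arm moves the number clearly, since they cover only hydrogen and methoxy; a chlorine, a fluorine, an amine or a carboxylic acid on the same ring could answer that. From the compounds shown here alone, it also remains open whether the flat response holds with a shorter or a longer chain linking the shared core to the amide.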